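The source may report more compounds than this note shows. Statements on the series, on what has been measured and on what is new or still open speak of the compounds shown alone.

Among the numbers so far in a functional assay on DU-145 cells (Homo sapiens) for cytotoxicity, read by trypan blue exclusion, with a stated time of 96 h (on this read-out lower numbers stand for stronger inhibition and higher numbers for weaker inhibition), compound 2 `COc1ccc(NS(=O)(=O)/C=C/c2cc(OC)c(OC)c(OC)c2)cc1[N+](=O)[O-]` stands highest at 75000 nM, while compound 1 `COc1ccc(NS(=O)(=O)/C=C/c2cc(OC)c(OC)c(OC)c2)cc1` gives 35000 nM. The next change leads to compound 3 `COc1ccc(NS(=O)(=O)/C=C/c2cc(OC)c(OC)c(OC)c2)cc1N`, which has amino in place of nitro on an aromatic carbon. This carbon lies ortho to a methoxy group and meta to a large group.

For the measured compounds named here, only one measured step bears on this change. Placing nitro on an aromatic carbon in place of hydrogen gave a 2.1-fold higher number from compound 1 to compound 2 (0.33 log units; beyond the scatter), which is modest but beyond the scatter. Amino has not been measured at this place, so that step shows only how nitro compares with hydrogen. Still, the removal of nitro suggests that compound 3 may return towards compound 1, and a lower number is expected in this assay. With a single step as evidence, neither its size nor its direction is secure. The expected change is a 3.8-fold lower number from compound 2 to compound 3 (0.57 log units; beyond the scatter). The estimate for compound 3 is 20000 nM, with an expected range of 2000 nM to 70000 nM.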

Compound 3, half-maximal inhibitory concentration: 35000 nM
Compound 3: middle estimate off by 1.8-fold (0.24 log units), on the low side, and the stated range covers the measured number.
By their numbers in this assay, from the lowest: compounds 1 and 3 (each within the scatter of the next); then compound 2.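

In this assay, amino in place of nitro gives a 2.1-fold lower number from compound 2 to compound 3 (0.33 log units; beyond the scatter), so the higher number seen with nitro at this carbon does not extend to every group placed there. Amino in place of hydrogen gives no change at the digits printed from compound 1 to compound 3 (within the scatter), which shows that this carbon, ortho to a methoxy group, can carry amino with a number that cannot be told apart from that of the hydrogen compound. Of the three compounds, nitro alone stands apart at this place, but nothing measured here gives a reason for the difference between nitro and amino.

On these data alone, it remains open whether other groups on this carbon, such as hydroxyl, methyl or an acetylated amine, would fall with compound 1 and compound 3 or with compound 2. As far as these compounds go, all three compounds also share the same methoxy group and the same core, and their numbers come only from this assay, so it is unknown whether amino and nitro would compare in the same way on a different core or in a different test.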